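The source may hold more compounds than are shown below. What is called first, only, known or untested is meant among the compounds shown, and "the series" means these compounds.

Compound 1 `COc1cc(OC)c2c(=O)cc(-c3ccc(OCc4cn(-c5ccc(F)cc5F)nn4)c(OC)c3)oc2c1` was tested in an ADME assay on Huh-7 cells (Homo sapiens) for cytotoxicity, read by MTT assay, with a stated time of 72 h; on this read-out higher numbers stand for lower toxicity in this test and lower numbers for higher toxicity in this test. In this assay compound 1 gives > 100 ug/mL, which is a limit of the assay rather than a number. Two other compounds share the same core fragment on the triazole side and were tested alongside it. Compound 2 `COc1cc(O)c(C(=O)/C=C/c2ccc(OC)c(OCc3cn(-c4ccc(F)cc4Cl)nn3)c2)c(OC)c1` gives > 100 ug/mL in this assay, again a limit. Compound 3 `COc1cc(O)c(C(=O)/C=C/c2ccc(OC)c(OCc3cn(-c4ccc(Cl)cc4)nn3)c2)c(OC)c1` gives > 100 ug/mL in this assay, also a limit. Among the measured compounds shown here, the one pairwise comparison available, a step that the two limits leave unreadable from compound 2 to compound 3, is therefore unreadable, and the only evidence on the set is that (the limit of > 100 ug/mL in this assay, at which 3 of the 3 values shown sit). Compound 4 `COc1cc(OC)c2c(=O)cc(-c3ccc(OCc4cn(-c5ccccc5Cl)nn4)c(OC)c3)oc2c1` has not yet been measured. It differs from compound 1 in one place: 2-chlorophenyl in place of 2,4-difluorophenyl on an aromatic nitrogen. For the measured compounds named here, the step from compound 2 to compound 3 also exchanges the aryl group on the aromatic nitrogen and gives no readable size, so there is no basis for expecting compound 4 to move out of the range in which every compound so far has sat. The expectation for compound 4 is 100 ug/mL, between 60 ug/mL and 150 ug/mL, which corresponds to an estimated step of a number no higher from compound 1 to compound 4 (the limit leaves the size open) from compound 1 to compound 4, most likely reported again as a limit.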

Compound 4, half-maximal cytotoxic concentration: > 100 ug/mL
Compound 4 ended at the assay's limit; the forecaster's own chance of this, stated with the estimate: 85%; the middle value sits exactly at the limit.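

No new step can be read: compound 1 and compound 4 both sit at a limit in this assay, so the exchange of 2,4-difluorophenyl for 2-chlorophenyl has no readable size, and the set offers only this: the limit of > 100 ug/mL in this assay, at which 4 of the 4 values shown sit.

The compounds shown leave open whether changing the aryl group on the aromatic nitrogen alters the read-out in this assay at all.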